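A few compounds are considered here, and "the series" means these few. Any claim that something is new, unique, unknown or untested is made for them only; others in the source may bear on it.

Measured so far:
Compound 1 `CCNc1nc(=O)c2cc(C(F)(F)F)cc([N+](=O)[O-])c2s1` is a limit in an ADME assay on Vero cells (Chlorocebus sabaeus) for cytotoxicity, read by MTT assay, with a stated time of 72 h (on this read-out higher numbers stand for weaker inhibition and lower numbers for stronger inhibition), at > 100000 nM.
Compound 2 `O=c1nc(NC2CC2)sc2c([N+](=O)[O-])cc(C(F)(F)F)cc12` is likewise a limit in this assay, at > 100000 nM.

Compound 2 therefore stands only at the cut-off of this assay, not at a number, and the same is true of the limit of > 100000 nM in this assay, at which 2 of the 2 values shown sit. Going by the values given here, the one measured step, a step that the two limits leave unreadable from compound 1 to compound 2, is unreadable for that reason.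

Compound 3 `CC1CCN(c2nc(=O)c3cc(C(F)(F)F)cc([N+](=O)[O-])c3s2)CC1` differs from compound 2 by 4-methylpiperidin-1-yl in place of cyclopropylamino on an aromatic carbon. With no readable step to draw on, compound 3 is expected to stay at the cut-off as well, so the expected step of a number no higher from compound 2 to compound 3 (the limit leaves the size open) is none beyond the scatter. The estimate for compound 3 is 100000 nM, within 30000 nM to 300000 nM.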

Compound 3, half-maximal inhibitory concentration: > 100000 nM
Compound 3 was reported as a limit; the forecaster's own chance of this, stated with the estimate: 85%; the middle value lies on the limit itself.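

No step can be read among compound 1, compound 2 and compound 3, because each result is a limit and not a number: the limit of > 100000 nM in this assay, at which 3 of the 3 values shown sit.

Where each compound truly lies in this assay, and whether changing the group on the aromatic carbon matters at all, stays open.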